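A methyl gives way to cyano

The source may report more compounds than this note shows. Statements on the series, on what has been measured and on what is new or still open speak of the compounds shown alone.

Two compounds have been measured so far in an ADME assay on MT4 cells (Homo sapiens) for cytotoxicity, read by MTT assay, with a stated time of 5 days (a higher number here means that more compound is tolerated, a lower number that less compound is tolerated), and they read as follows:
- compound 1 (`Cc1cc(C#N)cc(C)c1Oc1cc(Nc2ccc(C#N)cc2)[nH]c(=O)c1Cl`) gives > 319000 nM as a limit of the assay
- compound 2 (`Cc1cc(C)c(Oc2cc(Nc3ccc(C#N)cc3)[nH]c(=O)c2)c(C)c1`) gives 32000 nM as a number

Going by the values given here, compound 2 therefore holds the only actual number in the set, and no second number exists to rank it against. Compound 3 (`Cc1cc(C#N)cc(C)c1Oc1cc(Nc2ccc(C#N)cc2)[nH]c(=O)c1`) has not yet been measured. It differs from compound 2 by one change (cyano in place of methyl on an aromatic carbon), with cyano in place of methyl on an aromatic carbon, meta to two methyl groups and para to a large group.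

Among the compounds with values here, no measured pair shows this change on its own, so the size of the step in this assay remains uncertain. A modest upward move just beyond the scatter is expected, meaning more compound tolerated. That direction leans on compound 1, whose > 319000 nM is a limit of the assay. In numbers, the estimated move is a 2.5-fold higher number from compound 2 to compound 3 (0.40 log units; beyond the scatter) on this reckoning. For compound 3 the estimate is 80000 nM with an expected range from 20000 nM to 350000 nM and the reading may also come back as a limit.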

Compound 3, half-maximal cytotoxic concentration: 25000 nM
Compound 3: middle estimate off by 3.2-fold (0.51 log units), on the high side; the range from low to high includes it.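

In this assay, cyano in place of methyl on an aromatic carbon, meta to two methyl groups and para to a large group, gives a 1.3-fold lower number from compound 2 to compound 3 (0.11 log units; within the scatter), so on this evidence the exchange at this position leaves compound 2 and compound 3 reading alike. The large separation lies elsewhere, with hydrogen in place of chloro on an aromatic carbon, which gives an at least 12-fold lower number from compound 1 to compound 3 (1.10 log units; beyond the scatter), so in this pair the chloro rather than the cyano marks the step beyond the scatter. Compound 1 gives > 319000 nM, which is a limit of the assay, so that step has a floor but no measured size: the limit of > 319000 nM in this assay, at which 1 of the 3 values shown sits.

The compounds shown leave open how far the reading would go with chloro present, and whether the same chloro step would appear with methyl in place of cyano, as no pair isolates it in that setting. They also leave open whether a bromo or an amine on the carbon that carries chloro in compound 1, or a carboxylic acid in place of the cyano, would separate from compound 3 in this assay.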